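The source may report more compounds than this note shows. Statements on the series, on what has been measured and on what is new or still open speak of the compounds shown alone.

Series notes, measured in a physicochemical assay for solubility, in phosphate buffer, at pH 7.4; a lower number here means a less soluble compound, a higher number a more soluble compound

Compound 1 `CCOC(=O)c1c(-c2cccc([N+](=O)[O-])c2)[nH]c2cc(OC)ccc2c1=O` gives 13000 nM
Compound 2 `CCOC(=O)c1c(-c2cccs2)[nH]c2cc(OC)ccc2c1=O` gives > 100000 nM

Compound 2 stands at > 100000 nM, which is a limit of the assay and not a number. Among the measured compounds shown here, that limit is the top of what has been seen so far in this assay, and no measured compound lies on a number higher than compound 1 apart from it.

The next compound is compound 3 `CCOC(=O)c1c(-c2ccc(Cl)cc2)[nH]c2cc(OC)ccc2c1=O`, with 4-chlorophenyl in place of thiophen-2-yl on an aromatic carbon, next to the ring nitrogen and ortho to an ethoxycarbonyl group: 4-chlorophenyl in place of thiophen-2-yl on an aromatic carbon.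

For the measured compounds named here, one measured step bears on this, at the same place on the shared core. It is an at least 7.6-fold higher number from compound 1 to compound 2 (0.88 log units; beyond the scatter), thiophen-2-yl in place of 3-nitrophenyl. The change to compound 3 runs the opposite way, from thiophen-2-yl back to a substituted phenyl, though with a different substituent, so this single step is only a rough guide. A drop of similar size, beyond the scatter, is expected towards a lower number, estimated as an at least 10-fold lower number from compound 2 to compound 3 (1.00 log units; beyond the scatter). For compound 3 the expected value in this assay is 10000 nM, with an estimated range of 2500 nM to 40000 nM.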

Compound 3, solubility: 3000 nM
For compound 3 the middle estimate is 3.3-fold (0.52 log units) above the measured one; low and high end bracket the measured number.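

In this assay, the place next to the ring nitrogen and ortho to an ethoxycarbonyl group now has three aromatic groups to compare, and the swap of thiophen-2-yl for 4-chlorophenyl gives the largest step seen so far: an at least 33-fold lower number from compound 2 to compound 3 (1.52 log units; beyond the scatter). The two substituted phenyl groups do not read alike either, with 4-chlorophenyl in place of 3-nitrophenyl giving a 4.3-fold lower number from compound 1 to compound 3 (0.64 log units; beyond the scatter), so compound 3 holds the lowest number of the three and a phenyl ring at this place does not fix the read-out at one level. Compound 2 stands at a limit of the assay and not at a number, so the first of these steps gives only a minimum size: the limit of > 100000 nM in this assay, at which 1 of the 3 values shown sits.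

3-nitrophenyl and 4-chlorophenyl differ both in the substituent and in where it sits on the phenyl ring, and the compounds shown cannot separate the two. On these data alone, an unsubstituted phenyl, or a phenyl carrying an amine or a carboxylic acid, lies outside these compounds, so it remains open how much of the gap to thiophen-2-yl belongs to the ring itself and how much to its substituent.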